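Same Small Swap, Measured Once and Expected Again

This account rests on a few compounds, and the source may have more. Where it says the series, first, only, none or still open, it means among the compounds named here.

All compounds here were tested in a functional assay on MDA-MB-453 cells (Homo sapiens) for cytotoxicity, read by MTT assay, with a stated time of 48 h; on this read-out lower numbers stand for stronger inhibition and higher numbers for weaker inhibition. Compound 1, `COc1cc(C#N)ccc1OCc1nnc(-c2ccc(C)cc2)o1`, gives 38400 nM in this assay. Compound 2, `COc1cc(C#N)ccc1OCc1nnc(-c2ccc(F)cc2)o1`, differs from compound 1 by one change, (fluoro in place of methyl on an aromatic carbon); in this assay compound 2 gives 10500 nM. That change brought a 3.7-fold lower number from compound 1 to compound 2 (0.56 log units; beyond the scatter).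

Compound 3, `Cc1ccc(-c2nnc(COc3ccc(C#N)c(F)c3)o2)cc1`, carries a different core from compound 1; how the two cores differ is not broken down here. In this assay compound 3 reaches only a limit, > 50000 nM. This is the limit of > 50000 nM in this assay, at which 1 of the 3 values shown sits.

Compound 4, `N#Cc1ccc(OCc2nnc(-c3ccc(F)cc3)o2)cc1F`, has not yet been measured. It stands to compound 3 as compound 2 stands to compound 1: the change is fluoro in place of methyl on an aromatic carbon. Among the measured compounds shown here, the description of the place is the same word for word in both pairs, so this can be called the same change, and the one measured step is the only guide to what it may do on the other core.

For compound 4 a step of about an at least 2.0-fold lower number from compound 3 to compound 4 (0.30 log units; that floor lies within the scatter) is expected, resting on a 3.7-fold lower number from compound 1 to compound 2 (0.56 log units; beyond the scatter). The starting point is uncertain: for compound 3 only a limit is known, > 50000 nM. Compound 4 is therefore estimated at 25000 nM, with a range from 8000 nM to 80000 nM, and a real chance that this assay again reports only a limit.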

Compound 4, half-maximal inhibitory concentration: 25100 nM
Estimate against measurement, compound 4: 1.0-fold (0.00 log units) below; the measured number falls inside the stated range.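

In this assay, replacing 4-methylphenyl with 4-fluorophenyl on the second core gave an at least 1.9-fold lower number from compound 3 to compound 4 (0.29 log units; that floor lies within the scatter), which points the same way as the step on the first core, although only two cores are shown and that is too few for a general rule. Setting the two steps side by side does not show whether the change has the same size on both cores, so the agreement extends to direction and not to a shared size: the same change on two cores in this assay, a 3.7-fold lower number (0.56 log units; beyond the scatter) from compound 1 to compound 2 and an at least 1.9-fold lower number (0.29 log units; that floor lies within the scatter) from compound 3 to compound 4; the limit leaves it open whether they differ. Compound 3 has only a limit, > 50000 nM, rather than a true number, and it is the only compound shown with one: the limit of > 50000 nM in this assay, at which 1 of the 4 values shown sits.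

The compounds shown leave open whether the same swap would give a lower number on a core that differs in some further way, and whether it would do so in a different cell line. They also leave open how other groups in that same place would compare with methyl and fluoro, for example chloro, trifluoromethyl, an amine or a carboxylic acid.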